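The compounds below may be only part of what the source reports. "The series", "measured", "known", "first", "only" and "open" are said of these compounds alone.

Compound 1 `CCc1c(F)c(N)c2c(=O)cc(-c3ccc(N)c(F)c3)oc2c1F` is the reference point of the series. In a functional assay on HeLa cells (Homo sapiens) for cytotoxicity, read by neutral red uptake, with a stated time of 3 days (a higher number here means a weaker inhibitor, a lower number a stronger inhibitor), compound 1 gives only a limit, > 100000 nM. Compound 2 `Nc1ccc(-c2cc(=O)c3c(N)c(F)c(Cl)c(F)c3o2)cc1F` likewise gives only a limit in this assay, > 100000 nM. Within the data shown here, compound 3 `CCC(=O)OCc1c(F)c(N)c2c(=O)cc(-c3ccc(N)c(F)c3)oc2c1F` is the one member with a number in this assay, 69000 nM. Given (the limit of > 100000 nM in this assay, at which 2 of the 3 values shown sit), the step that the two limits leave unreadable from compound 1 to compound 2 cannot be read, while an at least 1.4-fold lower number from compound 1 to compound 3 (0.16 log units; that floor lies within the scatter) and an at least 1.4-fold lower number from compound 2 to compound 3 (0.16 log units; that floor lies within the scatter) are floors that lie within the scatter. Compound 4 `COCc1c(F)c(N)c2c(=O)cc(-c3ccc(N)c(F)c3)oc2c1F` is not yet measured in this assay. Its change from compound 1 is methoxy in place of methyl on a saturated chain carbon bound to an aromatic carbon; cut one bond further out, the same difference reads ethyl to methoxymethyl. Among the measured compounds shown here, none of the measured steps concerns a methoxy group, and none exceeds the scatter, so no shift beyond the scatter is expected in this assay for compound 4. The expected step of a number no higher from compound 1 to compound 4 (the limit leaves the size open) is therefore small. Compound 4 is estimated at 100000 nM, between 40000 nM and 300000 nM, with a fair chance that this assay again reports only a limit.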

Compound 4, half-maximal inhibitory concentration: > 100000 nM
Compound 4 gave a limit, no number (the forecaster's own chance of this, stated with the estimate: 55%); the middle value sits exactly at the limit.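

In this assay compound 4 gives > 100000 nM, which is a limit and not a number, so methoxy in place of methyl on this saturated chain carbon yields no measurable value. Among these compounds, the one readable step is an at least 1.4-fold higher number from compound 3 to compound 4 (0.16 log units; that floor lies within the scatter), so methyl in place of propanoyl on the oxygen on a saturated carbon shows no separation beyond the scatter. The steps to this compound from the ethyl and chloro compounds cannot be read, as both ends of each are limits: the limit of > 100000 nM in this assay, at which 3 of the 4 values shown sit.

From the compounds shown here alone, it remains open whether any group on this carbon can give a number clearly beyond the scatter from these limits. Also open, going by these compounds, is what an amine, a carboxylic acid or a longer chain would give here in this assay.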